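Carbamate terminus change on the piperidine carbonyl: compound 4

A few compounds are considered here, and "the series" means these few. Any claim that something is new, unique, unknown or untested is made for them only; others in the source may bear on it.

Compound 3 `CC(C)(C)OC(=O)N1CCC(Oc2ncnc3c2CCN3c2ccc(S(C)(=O)=O)cc2F)CC1` gives 20 nM in a functional assay on CHO-K1 cells for agonist activity at Glucose-dependent insulinotropic receptor (Homo sapiens), read by a luciferase reporter, with a stated time of 5 h (a higher number here means that more compound is needed for the effect, a lower number that less compound is needed), the lowest of the three numbers in hand. Compound 1 `CC(C)OC(=O)N1CCC(Oc2ncnc3c2CCN3c2ccc(-c3nccs3)cc2F)CC1` gives 79.4 nM in this assay, and compound 2 `CC(C)OC(=O)N1CCC(Oc2ncnc3c2CCN3c2ccc(-c3cccn3C)cc2F)CC1` gives 158 nM in this assay. For the measured compounds named here, the only single-point step known, a 2.0-fold higher number from compound 1 to compound 2 (0.30 log units; within the scatter), changes the aromatic substituent and lies within the scatter; compound 3 stands beyond the scatter from both of these in the lower direction.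

Compound 4 `CSC(=O)N1CCC(Oc2ncnc3c2CCN3c2ccc(S(C)(=O)=O)cc2F)CC1` differs from compound 3 by methylsulfanyl in place of tert-butoxy on a carbonyl carbon. Going by the values given here, no measured step touches the carbonyl substituent, so the series gives no direct reading on this change; the step from compound 1 to compound 2 concerns a different part of the molecule and bears on it only in showing that single changes elsewhere have stayed within the scatter. With no guidance either way, a modest shift upward is expected in this assay, a 2.5-fold higher number from compound 3 to compound 4 (0.40 log units; beyond the scatter), with wide uncertainty. Compound 4 is estimated at 50 nM, with the range 15 nM to 200 nM.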

Compound 4, half-maximal effective concentration: 251 nM
Estimate against measurement, compound 4: 5.0-fold (0.70 log units) below; the whole stated range lies below it.
By their numbers in this assay, from the lowest: compound 3; then compounds 1, 2 and 4 (each within the scatter of the next, the first and the last beyond it).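

For the compounds shown here, the group on the carbonyl carbon is the first place where a single change moves the read-out beyond the scatter: in this assay, methylsulfanyl in place of tert-butoxy gives a 13-fold higher number from compound 3 to compound 4 (1.10 log units; beyond the scatter). Going by these compounds alone, the only earlier single-place step, a 2.0-fold higher number from compound 1 to compound 2 (0.30 log units; within the scatter), concerned the aromatic substituent and stayed within the scatter. This exchange changes the heavy-atom count and replaces oxygen with sulfur at once, the two cannot be separated here, and no measurement bears on the cause of the step.

A methoxy or tert-butylsulfanyl group on the same carbonyl carbon would part the sulfur from the heavy-atom count, and neither is among the compounds shown. Also open, from the compounds shown here alone, is whether the step carries over to compounds with a different aromatic substituent.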